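Swapping methoxy for an arylamino group on the shared core

This account rests on a few compounds, and the source may have more. Where it says the series, first, only, none or still open, it means among the compounds named here.

Compound 1 (`C=C[C@@](C)(/C=C/c1ccc(OC)cc1)CCC=C(C)C`) gives > 36600 nM as a limit
Compound 2 (`C=C[C@@](C)(/C=C/c1ccc(O)cc1)CC/C=C/C(=O)c1ccccc1`) gives > 36600 nM as a limit
Compound 3 (`C=C[C@@](C)(/C=C/c1ccc(O)c(C=O)c1)CCC=C(C)C`) gives 8510 nM as a number

These figures all come from a functional assay on SEM cells (Homo sapiens) for cytotoxicity, with a stated time of 72 h (on this read-out higher numbers stand for an effect only at larger amounts of compound and lower numbers for an effect already at smaller amounts), and nothing else. Compound 1 stands at the limit of > 36600 nM in this assay, at which 2 of the 3 values shown sit, and has no exact value of its own. Compound 4 (`C=C[C@@](C)(/C=C/c1ccc(Nc2cc(F)cc(F)c2)cc1)CCC=C(C)C`) has not yet been measured. Its difference from compound 1 is counted here ((3,5-difluorophenyl)amino in place of methoxy on an aromatic carbon) and amounts to (3,5-difluorophenyl)amino in place of methoxy on an aromatic carbon.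

Among the compounds with values here, no measured pair shows what this swap does, so any expectation is a judgement. Compound 3 reaches 8510 nM as a real number in this series, which suggests that a change on this ring can bring a measurable effect. A move towards a lower number is therefore expected, though compound 4 could also remain at the limit. The expected step is an at least 3.3-fold lower number from compound 1 to compound 4 (0.52 log units; beyond the scatter) as estimated here. Compound 4 is expected at 11000 nM by this estimate, with a likely range from 3000 nM to 36000 nM around it.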

Compound 4, half-maximal effective concentration: > 36600 nM
Compound 4: no number, only a limit; the forecaster's own chance of this, stated with the estimate: 30%; middle value at least 3.3-fold (0.52 log units) away from the limit.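

Within the data shown here, compound 1 and compound 4 both give only a limit, not a number, in this assay, so no step between them can be read: the limit of > 36600 nM in this assay, at which 3 of the 4 values shown sit. The compounds shown leave open whether (3,5-difluorophenyl)amino in place of methoxy changes the effect at all, and in which direction.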